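Notes on compound 3: cyclohexyl in place of methyl

This account rests on a few compounds, and the source may have more. Where it says the series, first, only, none or still open, it means among the compounds named here.

Measured so far:
compound 1 `C[C@H]1CC(Cl)=C([Si](C)(C)C)[C@@H](C2CCCCC2)O1`: 17000 nM in a functional assay on A2780 cells (Homo sapiens) for antiproliferative activity; on this read-out lower numbers stand for stronger inhibition of growth and higher numbers for weaker inhibition of growth
compound 2 `C[C@H]1CC(Cl)=C[C@@H](C2CCCCC2)O1`: 19000 nM in this assay

Compound 1 and compound 2 sit within the scatter of each other, so neither can be told apart from the other on these numbers. Going by the values given here, the one measured step, a 1.1-fold higher number from compound 1 to compound 2 (0.05 log units; within the scatter), shows that putting a hydrogen atom in place of the group of four heavy atoms on the double-bonded ring carbon leaves the read-out where it was.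

Compound 3 `C[Si](C)(C)C1=C(Cl)C[C@H](C2CCCCC2)O[C@@H]1C1CCCCC1` is not yet measured in this assay. It differs from compound 1 by cyclohexyl in place of methyl on a saturated ring carbon. Among the compounds with values here, the measured step concerns another position and another kind of group, so no measured step bears on this change, and there is no basis for expecting a shift in either direction. The estimate therefore rests on compound 1 with 17000 nM and carries a wide range. For compound 3 the expected value in this assay is 17000 nM, with a range of 4000 nM to 60000 nM. The expected step of no change at the digits printed from compound 1 to compound 3 (within the scatter) is taken as none beyond the scatter.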

Compound 3, concentration for 50% growth inhibition: 22000 nM
Beside the measured number, compound 3's estimate is 1.3-fold (0.11 log units) below it; measured number inside the range.
By their numbers in this assay, from the lowest: compounds 1, 2 and 3 (each within the scatter of the next).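

In this assay, going by these compounds alone, cyclohexyl in place of methyl on the saturated ring carbon next to the ring oxygen gives a 1.3-fold higher number from compound 1 to compound 3 (0.11 log units; within the scatter), which is the first reading at this position. Going from methyl to cyclohexyl, with a six-membered non-aromatic ring of carbon only entering, therefore leaves the read-out within the scatter, as does the change on the double-bonded ring carbon, a 1.1-fold higher number from compound 1 to compound 2 (0.05 log units; within the scatter), so neither of the two positions probed so far has yet moved the number beyond the scatter. Nothing measured here offers an explanation for this flat result.

Still open, going by these compounds, is whether any group at this saturated ring carbon can move the read-out beyond the scatter, for example an amine, a carboxylic acid or a longer chain in place of the cyclohexyl group of compound 3. On these data alone, it is also open whether a hydrogen atom at this position would give a number within the scatter of compound 1, and whether the same cyclohexyl change would read the same way on the core of compound 2, which lacks the group of 4 heavy atoms.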